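Swapping a Fluorinated Ring for a Methylphenyl

This account rests on a few compounds, and the source may have more. Where it says the series, first, only, none or still open, it means among the compounds named here.

Compound 1 `O=C(NCCO)c1cccc2c1CCN2c1cc(Cc2cc(F)cc(C(F)(F)F)c2)ncn1` is the stronger of two compounds tested in a functional assay on HEK293 cells for agonist activity at G-protein coupled receptor 52 (Homo sapiens), read by cAMP accumulation, with a stated time of 15 min (on this read-out lower numbers stand for an effect already at smaller amounts and higher numbers for an effect only at larger amounts of compound), where compound 1 gives 135 nM. Compound 2 `Cc1c(Cc2cc(F)cc(C(F)(F)F)c2)cnnc1N1CCc2c(C(=O)NCCO)cccc21` has a differently built core and gives 754 nM in this assay, a gap that lies beyond the scatter of this kind of measurement. Compound 3 `Cc1cccc(Cc2cc(N3CCc4c(C(=O)NCCO)cccc43)ncn2)c1` has not yet been measured. It differs from compound 1 in one place only: 3-methylphenyl in place of 3-fluoro-5-(trifluoromethyl)phenyl on a saturated chain carbon bound to an aromatic carbon. For the measured compounds named here, no measured pair shows what such an exchange does on this core, so the expectation rests on compound 1 alone. The fluorinated ring is removed and a simpler ring with a single methyl takes its place; in this assay the step is expected to be a loss, a 4.1-fold higher number from compound 1 to compound 3 (0.61 log units; beyond the scatter), of a size beyond the scatter. Compound 3 is therefore expected to give 550 nM in this assay, most likely between 180 nM and 2000 nM.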

Compound 3, half-maximal effective concentration: 90 nM
For compound 3 the middle estimate is 6.1-fold (0.79 log units) above the measured one, outside the stated range (below it).
By their numbers in this assay, from the lowest: compounds 3 and 1 (each within the scatter of the next); then compound 2.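

In this assay, replacing 3-fluoro-5-(trifluoromethyl)phenyl with 3-methylphenyl gives a 1.5-fold lower number from compound 1 to compound 3 (0.18 log units; within the scatter). For the compounds shown here, this is the first measured exchange at this place on the shared core, and it shows that here the four fluorine atoms can be given up, with the group shrinking from 11 heavy atoms to 7, without a change that stands out from the scatter. Nothing shown accounts for why these two rings give values so close to each other. From the compounds shown here alone, it remains open whether the single methyl matters at all, since plain phenyl would test that directly, and whether a methoxy group or a chlorine in its place would keep the value at this level. Also open, going by these compounds, is whether a pyridine ring could stand in for the carbon-only ring.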